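This account rests on a few compounds, and the source may have more. Where it says the series, first, only, none or still open, it means among the compounds named here.

Working notes on the series built on the shared core of compound 1 `COc1ccc([C@H]2CC(=O)N(C(C)=O)C2)cc1OC1CCCC1`. In a functional assay on HEK293 cells (Homo sapiens) for cytotoxicity (a lower number here means that less compound is tolerated, a higher number that more compound is tolerated), compound 1 gives > 10000 nM, which is a limit of the assay and not a number. Compound 2 `COc1ccc([C@H]2CC(=O)N(c3ccccc3C#N)C2)cc1OC1CCCC1` carries a 2-cyanophenyl on an amide-type nitrogen in a ring; in this assay compound 2 gives > 10000 nM, again a limit rather than a measured number. Compound 3 `COc1ccc([C@H]2CC(=O)N(c3cccc(C(F)(F)F)c3)C2)cc1OC1CCCC1` carries a 3-(trifluoromethyl)phenyl on an amide-type nitrogen in a ring; in this assay compound 3 gives > 10000 nM, also a limit. Going by the values given here, compound 2 thus stands where all three values so far stand, at the limit (the limit of > 10000 nM in this assay, at which 3 of the 3 values shown sit), and no ordering among compounds 1, 2 and 3 can be read.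

Compound 4 `COc1ccc([C@H]2CC(=O)N(c3cccc([S+](C)[O-])c3)C2)cc1OC1CCCC1` is not yet measured. Its change from compound 2 is a group of 9 heavy atoms (7 carbon, 1 oxygen, 1 sulfur; one six-membered aromatic ring of carbon only) in place of a group of 8 heavy atoms (7 carbon, 1 nitrogen; one six-membered aromatic ring of carbon only), on an amide-type nitrogen in a ring.

The measured steps that bear on this change are a step that the two limits leave unreadable from compound 2 to compound 3, a step that the two limits leave unreadable from compound 1 to compound 2 and a step that the two limits leave unreadable from compound 1 to compound 3. None of them has a readable size because every value sits at the limit (the limit of > 10000 nM in this assay, at which 3 of the 3 values shown sit). There is therefore no evidence for any step beyond the scatter, and compound 4 is expected to show a step that the limit leaves unreadable from compound 2 to compound 4. Compound 4 is estimated at 15000 nM, with a range from 8000 nM to 40000 nM, and is most likely to be reported once more as a limit.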

Compound 4, half-maximal cytotoxic concentration: > 10000 nM
Compound 4 gave a limit, no number (the forecaster's own chance of this, stated with the estimate: 85%); the middle value lies beyond the limit too.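

In this assay compound 4 also gives only a limit, so its steps from compound 1, compound 2 and compound 3 cannot be read: the limit of > 10000 nM in this assay, at which 4 of the 4 values shown sit.

The compounds shown leave open whether the groups on the amide-type nitrogen in a ring differ at all in this assay, as none of compounds 1 to 4 has a value short of the limit.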